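Alkoxy and alkylthio variation on the shared core: cytotoxicity

The source may hold more compounds than are shown below. What is called first, only, known or untested is meant among the compounds shown, and "the series" means these compounds.

Compound 1 `CCCCCOc1nc(N)nc2c1ncn2/C=C1/CC1(CO)CO`: in an ADME assay on CCRF-HSB-2 cells (Homo sapiens) for cytotoxicity, with a stated time of 7 days (on this read-out higher numbers stand for lower toxicity in this test and lower numbers for higher toxicity in this test), compound 1 gives > 20000 nM, a limit of the test.
Compound 2 `CCCCCCSc1nc(N)nc2c1ncn2/C=C1/CC1(CO)CO`: in this assay compound 2 gives 60000 nM.

Among the compounds with values here, compound 2 holds the only number in this assay; the other value is a limit. Within the data shown here, the single step, a step that the limit leaves unreadable from compound 1 to compound 2, is unreadable because of the limit of > 20000 nM in this assay, at which 1 of the 2 values shown sits. Compound 3 `CCOc1nc(N)nc2c1ncn2/C=C1/CC1(CO)CO` differs from compound 2 in ethoxy in place of hexylsulfanyl on an aromatic carbon. Among the measured compounds shown here, no measured step bears readably on this change, so no step beyond the scatter is expected in this assay. Compound 3 is estimated at 50000 nM, within 15000 nM to 150000 nM, an expected step of a 1.2-fold lower number from compound 2 to compound 3 (0.08 log units; within the scatter).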

Compound 3, half-maximal cytotoxic concentration: > 20000 nM
Compound 3 was reported as a limit; the forecaster's own chance of this, stated with the estimate: 55%; the middle value lies beyond the limit too.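

In this assay compound 3 gives > 20000 nM as a limit, and no step among compound 1, compound 2 and compound 3 can be read: the limit of > 20000 nM in this assay, at which 2 of the 3 values shown sit.

Still open, on these data alone, is whether ethoxy, pentyloxy and hexylsulfanyl on the shared core differ at all in cytotoxicity.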